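The compounds below may be only part of what the source reports. "The series", "measured", "known", "first", "only" and "open" are said of these compounds alone.

Of the compounds shown here, three have so far been tested in a functional assay on the whole organism (strain albino) for inhibition, with Rattus norvegicus as the target, read by paw edema, with stated times of 30 min and 4 h, at a dose of 100 mg/kg by the oral route; a lower number here means less inhibition, a higher number more inhibition at the dose given (going by the name of the read-out). Compound 1 `COc1ccc(/C=C/C(=O)c2ccc(NC(=O)CBr)cc2)cc1` gives 41%, compound 2 `COc1ccc(/C=C/C(=O)c2ccc(NC(=O)CO[N+](=O)[O-])cc2)cc1` gives 51%, and compound 3 `CC(Br)C(=O)Nc1ccc(C(=O)/C=C/c2ccc(Cl)cc2)cc1` gives 54%. Within the data shown here, the single step measured, a number 10 percentage points higher from compound 1 to compound 2 (within the scatter), lies within the scatter. Compound 3 stands highest of the three numbers: its gap to compound 2 is within the scatter, while its gap to compound 1 is beyond it, so only compound 1 is clearly apart from it.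

Compound 4 `COc1ccc(/C=C/C(=O)c2ccc(NC(=O)C(C)Br)cc2)cc1` differs from compound 3 in one place: methoxy in place of chloro on an aromatic carbon. Among the measured compounds shown here, no measured step bears on this change. For the measured compounds named here, the one step known, from compound 1 to compound 2, concerns a saturated chain carbon bound to a carbonyl carbon and says nothing about a substituent on the aromatic ring. Going by the values given here, with no step to lean on, the expected change is a number 4 percentage points lower from compound 3 to compound 4 (within the scatter), that is, none beyond the scatter. Compound 4 is therefore estimated at 50% in this assay, with a range from 36% to 62%.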

Compound 4, a percentage reported as inhibition, in the whole organism at one dose (the size of the read-out at that dose, not a potency): 38%
The estimate for compound 4 lay 12 percentage points above the measured number; measured number inside the range.
By their numbers in this assay, from the lowest: compounds 4, 1, 2 and 3 (each within the scatter of the next, the first and the last beyond it).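

In this assay, among these compounds, the change from 4-chlorophenyl to 4-methoxyphenyl, on an aromatic carbon para to a large group, gives the first measured step at this position: a number 16 percentage points lower from compound 3 to compound 4 (beyond the scatter). On the other side of the molecule, with the methoxy group kept, adding a methyl to the chain carbon that carries the bromine gives a number 3 percentage points lower from compound 1 to compound 4 (within the scatter), whereas 1-bromoethyl in place of (nitrooxy)methyl on the carbonyl carbon gives a number 13 percentage points lower from compound 2 to compound 4 (beyond the scatter). No measurement shown here explains these differences.

The compounds shown carry only chloro or methoxy at this ring position, so how an amine or a fluoro group would read there stays open. Also open, on these data alone, is whether chloro in place of methoxy would give a similar step in a compound with the (nitrooxy)methyl chain.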